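Swapping tert-Butyl for Trifluoromethyl on a Weak Cytotoxic

The source may report more compounds than this note shows. Statements on the series, on what has been measured and on what is new or still open speak of the compounds shown alone.

Compound 3 `CC(C)(C)c1ccc(CN2C(=O)S/C(=C\c3cccc(N)c3)C2=O)cc1` is the weakest of the three measured compounds in a functional assay on FM3A cells (Mus musculus) for cytotoxicity, read by cell counting, with a stated time of 2 days (a lower number here means a stronger inhibitor, a higher number a weaker inhibitor), giving 188000 nM. Within the data shown here, compound 1 `CC(C)(C)c1ccc(CN2C(=O)S/C(=C\c3ccc(N)cc3)C2=O)cc1` gives 80000 nM in this assay, and the only single-site step, a 2.4-fold higher number from compound 1 to compound 3 (0.37 log units; beyond the scatter), concerns where the amino group sits. Among the measured compounds shown here, compound 2 `C=C(Br)C(=O)Nc1cccc(/C=C2\SC(=O)N(Cc3cccc(Cl)c3)C2=O)c1` gives 1700 nM, but it differs from compound 3 in several places at once, and no single step connects them. Compound 4 `Nc1cccc(/C=C2\SC(=O)N(Cc3ccc(C(F)(F)F)cc3)C2=O)c1` is compound 3 with trifluoromethyl in place of tert-butyl on an aromatic carbon. For the measured compounds named here, no measured step touches this part of the molecule, so there is nothing to lean on. The expected step for compound 4 is a 1.3-fold lower number from compound 3 to compound 4 (0.10 log units; within the scatter), within the scatter. Compound 4 is therefore estimated at 150000 nM, with a range from 60000 nM to 400000 nM.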

Compound 4, half-maximal inhibitory concentration: > 250000 nM
Compound 4 gave a limit, no number; the forecaster's own chance of this, stated with the estimate: 20%; middle value at least 1.6-fold (0.22 log units) from the limit.
By their numbers in this assay, from the lowest: compound 2; then compound 1; then compound 3. At a limit, above all of these: compound 4.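

Among these compounds, the swap of tert-butyl for trifluoromethyl on this aromatic carbon gives the first reading at this place in the molecule: an at least 1.3-fold higher number from compound 3 to compound 4 (0.12 log units; that floor lies within the scatter). Compound 4 yields only a limit of the assay, not a number: the limit of > 250000 nM in this assay, at which 1 of the 4 values shown sits. So trifluoromethyl does not lower the number here, though how far the true value lies past that limit cannot be told.

The compounds shown leave open what a methoxy group, an amine or a carboxylic acid would do on this same carbon. They also leave open whether this swap would behave alike on compound 1.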